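Swapping Nitro for Fluoro in a Flat Series

A few compounds are considered here, and "the series" means these few. Any claim that something is new, unique, unknown or untested is made for them only; others in the source may bear on it.

Three measured compounds share one core and differ only in a single group on an aromatic ring. In a functional assay on MCF7 cells (Homo sapiens) for cytotoxicity, read by MTT assay, with a stated time of 72 h (on this read-out higher numbers stand for weaker inhibition and lower numbers for stronger inhibition), compound 1 `COc1ccc(-c2cc(=O)c3c(O)cc(OCCCCN4CCN(C)CC4)c(OC)c3o2)cc1`, which carries methoxy there, gives 3980 nM. Compound 2 `COc1c(OCCCCN2CCN(C)CC2)cc(O)c2c(=O)cc(-c3ccc(C)cc3)oc12`, with methyl, gives 4020 nM. Compound 3 `COc1c(OCCCCN2CCN(C)CC2)cc(O)c2c(=O)cc(-c3ccc([N+](=O)[O-])cc3)oc12`, with nitro, gives 4090 nM. Compound 3 therefore stands level with the other two, since repeat measurements could not tell these numbers apart.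

The next compound, compound 4 `COc1c(OCCCCN2CCN(C)CC2)cc(O)c2c(=O)cc(-c3ccc(F)cc3)oc12`, has fluoro in place of nitro on an aromatic carbon, para to a large group, turning 4-nitrophenyl into 4-fluorophenyl: fluoro in place of nitro on an aromatic carbon.

Three measured steps change the group at that same place: a 1.0-fold higher number from compound 1 to compound 2 (0.00 log units; within the scatter), a 1.0-fold higher number from compound 1 to compound 3 (0.01 log units; within the scatter) and a 1.0-fold higher number from compound 2 to compound 3 (0.01 log units; within the scatter). All three lie within the scatter, so methoxy, methyl and nitro make no measurable difference in this assay. Fluoro itself has not been tested in this series, which leaves some uncertainty, but these steps give no reason to expect anything beyond the scatter.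

The expected step is a 1.0-fold lower number from compound 3 to compound 4 (0.01 log units; within the scatter), which would be within the scatter. Compound 4 is estimated at 4000 nM, with an expected range of 2300 nM to 7000 nM.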

Compound 4, half-maximal inhibitory concentration: 3860 nM
Estimate against measurement, compound 4: 1.0-fold (0.02 log units) above, within the range that was stated.
By their numbers in this assay, from the lowest: compounds 4, 1, 2 and 3 (each within the scatter of the next).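

In this assay, fluoro now joins methoxy, methyl and nitro at this place on the aromatic ring, and every step to it stays within the scatter: a 1.1-fold lower number from compound 3 to compound 4 (0.03 log units; within the scatter), a 1.0-fold lower number from compound 2 to compound 4 (0.02 log units; within the scatter) and a 1.0-fold lower number from compound 1 to compound 4 (0.01 log units; within the scatter). The change from nitro to fluoro is also the largest in the counted atoms so far, with three heavy atoms and two hydrogen-bond acceptors leaving and a single heavy atom with no acceptors entering, yet the number does not measurably move, so the flat stretch at this position now covers four groups rather than three. Nothing measured here explains why this position is so flat.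

The compounds shown leave open whether a group of another kind at this place, such as an amine, a carboxylic acid or a longer chain, would produce a step beyond the scatter. They also leave open whether the four groups would still read alike if something elsewhere on the shared core were changed, for all four compounds carry that same core.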